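Swapping an acetyl for a piperazine on a thienopyrimidine

The compounds below may be only part of what the source reports. "The series", "measured", "known", "first", "only" and "open" are said of these compounds alone.

Compound 1 `CNc1nc(NCCCN(C)C)c2sc(-c3ccc(C(F)(F)F)cc3)cc2n1` carries a trifluoromethyl group on its outer aromatic ring, and in a physicochemical assay for solubility, at pH 2 (on this read-out higher numbers stand for higher solubility and lower numbers for lower solubility), compound 1 gives 240 ug/mL. Compound 2 `CNc1nc(NCCCN(C)C)c2sc(-c3ccc(C(C)=O)cc3)cc2n1` is the same molecule with an acetyl in place of the trifluoromethyl. In this assay compound 2 is reported only as > 100 ug/mL, which is a limit of the assay rather than a number. The step that the limit leaves unreadable from compound 1 to compound 2 therefore cannot be sized, because of the limit of > 100 ug/mL in this assay, at which 1 of the 2 values shown sits. So compound 2 stands at an open-ended position: what is known is only that it sits at that limit.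

Compound 3 `CNc1nc(NCCCN(C)C)c2sc(-c3ccc(N4CCNCC4)cc3)cc2n1` is the next compound in the series, differing from compound 2 by piperazin-1-yl in place of acetyl on an aromatic carbon. Among the compounds with values here, no measured step involves a piperazin-1-yl, and the single measured step touching this position is unreadable, so the measured data give no size to expect in this assay for this change, in either direction. The step from compound 2 to compound 3 is estimated as a step that the limit leaves unreadable from compound 2 to compound 3. For compound 3 the expected solubility is 300 ug/mL, within a range from 100 ug/mL to 1000 ug/mL.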

Compound 3, solubility: > 100 ug/mL
Compound 3 was reported as a limit; the forecaster's own chance of this, stated with the estimate: 50%; the middle value is on the limit's open side.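

In this assay compound 3 is reported as > 100 ug/mL, which is a limit and not a number. No new step linking compound 3 to compound 1 or compound 2 can be read: the limit of > 100 ug/mL in this assay, at which 2 of the 3 values shown sit.

The compounds shown leave open how far the acetyl and piperazin-1-yl groups of compound 2 and compound 3 separate these compounds from compound 1, or from each other, in solubility.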